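Compound 4 after the limit of compound 3

A few compounds are considered here, and "the series" means these few. Any claim that something is new, unique, unknown or untested is made for them only; others in the source may bear on it.

In a functional assay on MDA-MB-231 cells (Homo sapiens) for cytotoxicity, read by MTT assay, with a stated time of 48 h (on this read-out lower numbers stand for stronger inhibition and higher numbers for weaker inhibition), compound 1 (`O=C(NCCCCC(c1ccc(F)cc1)c1ccc(F)cc1)Nc1ccc(Cl)cc1`) gives 7680 nM and compound 2 (`O=C(NCCCCC(c1ccc(F)cc1)c1ccc(F)cc1)Nc1cccc(C(F)(F)F)c1`) gives 3380 nM as measured numbers. Compound 3 (`Cc1cc(Cl)ccc1NC(=O)NCCCCC(c1ccc(F)cc1)c1ccc(F)cc1`) gives only a limit (> 20000 nM) and stands at the limit of > 20000 nM in this assay, at which 1 of the 3 values shown sits, in this series.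

Compound 4 (`O=C(NCCCCC(c1ccc(F)cc1)c1ccc(F)cc1)c1ccc(Cl)c(C(F)(F)F)c1`) differs from compound 3 by 4-chloro-3-(trifluoromethyl)phenyl in place of (4-chloro-2-methylphenyl)amino on a carbonyl carbon and so carries 4-chloro-3-(trifluoromethyl)phenyl in place of (4-chloro-2-methylphenyl)amino on a carbonyl carbon. On the amide-type nitrogen, 3-(trifluoromethyl)phenyl in place of 4-chlorophenyl gave a 2.3-fold lower number from compound 1 to compound 2 (0.36 log units; beyond the scatter) and 4-chloro-2-methylphenyl in place of 3-(trifluoromethyl)phenyl gave an at least 5.9-fold higher number from compound 2 to compound 3 (0.77 log units; beyond the scatter) in the same series. Compound 4 has no methyl, the change seen in an at least 2.6-fold higher number from compound 1 to compound 3 (0.41 log units; beyond the scatter) for that pair, so a modest step to a lower number is expected in this assay for this change. Among the compounds with values here, no measured step covers the loss of the amino nitrogen, so the range stays wide. The expected step is an at least 3.3-fold lower number from compound 3 to compound 4 (0.52 log units; beyond the scatter) on this estimate. Compound 4 is estimated at 6000 nM with an expected range from 2500 nM to 15000 nM in this read-out.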

Compound 4, half-maximal inhibitory concentration: 11700 nM
For compound 4 the middle estimate is 2.0-fold (0.29 log units) below the measured one; the measured number falls inside the stated range.
By their numbers in this assay, from the lowest: compound 2; then compounds 1 and 4 (each within the scatter of the next). At a limit, above all of these: compound 3.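

In this assay, 4-chloro-3-(trifluoromethyl)phenyl on the carbonyl carbon gives a 1.5-fold higher number from compound 1 to compound 4 (0.18 log units; within the scatter) in place of (4-chlorophenyl)amino, but a 3.5-fold higher number from compound 2 to compound 4 (0.54 log units; beyond the scatter) in place of (3-(trifluoromethyl)phenyl)amino, so the size of this change depends on which amino group leaves. In place of (4-chloro-2-methylphenyl)amino it gives an at least 1.7-fold lower number from compound 3 to compound 4 (0.23 log units; that floor lies within the scatter), and that figure is only a floor. Compound 3 remains a limit, not a number: the limit of > 20000 nM in this assay, at which 1 of the 4 values shown sits.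

From the compounds shown here alone, compound 4 loses the amino nitrogen and gains the chloro and trifluoromethyl pair in one change, so the share of each in these steps stays open. Going by these compounds, whether a nitrile on that ring, or a morpholine in place of the whole aryl group on the carbonyl carbon, would keep a measurable number in this assay also stays open.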